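The source may hold more compounds than are shown below. What is called first, only, known or untested is meant among the compounds shown, and "the series" means these compounds.

Measured so far in an ADME assay on MT4 cells (Homo sapiens) for cytotoxicity, read by MTT assay, with a stated time of 4 days; a lower number here means that less compound is tolerated, a higher number that more compound is tolerated:
- compound 1 `Cc1c(Cc2c(F)cccc2F)nc(N2CCN(C)CC2)[nH]c1=O`: > 75000 nM, a limit of the assay
- compound 2 `COc1ccccc1N1CCN(c2nc(Cc3c(F)cccc3F)c(C)c(=O)[nH]2)CC1`: 37000 nM

Among the compounds with values here, compound 2 holds the only true number in this assay so far, at 37000 nM. The one other result, that of compound 1, is a limit. Next comes compound 3 `Cc1c(Cc2c(F)cccc2F)nc(N2CCN(c3ccccn3)CC2)[nH]c1=O`, with pyridin-2-yl in place of 2-methoxyphenyl on an amine nitrogen in a ring. Within the data shown here, the one measured change on that nitrogen is an at least 2.0-fold lower number from compound 1 to compound 2 (0.30 log units; that floor lies within the scatter). That gives no firm size or direction, so the expected result in this assay is a 1.4-fold higher number from compound 2 to compound 3 (0.13 log units; within the scatter), with no shift beyond the scatter. The estimate for compound 3 is 50000 nM, with an expected range of 20000 nM to 100000 nM.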

Compound 3, half-maximal cytotoxic concentration: > 63000 nM
Compound 3 gave a limit, no number (the forecaster's own chance of this, stated with the estimate: 35%); at least 1.2-fold (0.10 log units) between middle value and limit.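

In this assay compound 3 gives a limit of the assay and not a number: the limit of > 63000 nM in this assay, at which 1 of the 3 values shown sits.
Pyridin-2-yl in place of 2-methoxyphenyl on this amine nitrogen gives an at least 1.7-fold higher number from compound 2 to compound 3 (0.23 log units; that floor lies within the scatter), so the floor of this step fixes no shift beyond the scatter.
Compound 1 and compound 3 both stand as limits, and the step between them cannot be read.

Open, going by these compounds, is where the true number of compound 3 lies. Also open, on these data alone, is whether a carboxylic acid or a longer alkyl chain on this nitrogen would move the number beyond the scatter.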